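This account rests on a few compounds, and the source may have more. Where it says the series, first, only, none or still open, it means among the compounds named here.

In an ADME assay on Caco-2 cells (Homo sapiens) for permeability, in the apical to basolateral direction (a lower number here means that the compound crosses the layer more slowly, a higher number that the compound crosses the layer faster), compound 1 (`CCc1nc2c(C)cc(C)nc2n1Cc1ccc(-c2c(-c3nn[nH]n3)cnc3ccccc23)cc1`) gives 0.1 10^-6 cm/s, while compound 2 (`CCCCn1c(=O)c2cccnc2n1Cc1ccc(-c2ccccc2-c2nn[nH]n2)cc1`) gives 1.78 10^-6 cm/s, the higher of the two numbers and a gap beyond the usual scatter. Compound 3 (`CCCCn1c(=O)c2cc(Cl)cnc2n1Cc1ccc(-c2ccccc2-c2nn[nH]n2)cc1`) matches compound 2 except for one change: chloro in place of hydrogen on an aromatic carbon. For the measured compounds named here, no measured pair shows what this swap does, so no shift beyond the scatter is expected in this assay. The expected change is a 1.1-fold lower number from compound 2 to compound 3 (0.05 log units; within the scatter). For compound 3 the estimated value is 1.6 10^-6 cm/s, with a range from 0.5 10^-6 cm/s to 4.5 10^-6 cm/s.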

Compound 3, apparent permeability: 10.8 10^-6 cm/s
The estimate for compound 3 lay 6.8-fold (0.83 log units) below the measured number, and the stated range ends below it.
By their numbers in this assay, from the lowest: compound 1; then compound 2; then compound 3.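

In this assay, chloro in place of hydrogen on this aromatic carbon, two atoms from the ring nitrogen, gives a 6.1-fold higher number from compound 2 to compound 3 (0.78 log units; beyond the scatter) and so shows that one added heavy atom at this position can move the number beyond the scatter. For the compounds shown here, this is the first measured pair for this swap, so the finding rests on a single step. Nothing measured here accounts for the rise.

From the compounds shown here alone, whether fluoro, methyl or an amine at this position would move the number the same way stays open. So does whether chloro would have this effect on a different core.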